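One substituent exchanged on a carbonyl carbon

The source may report more compounds than this note shows. Statements on the series, on what has been measured and on what is new or still open speak of the compounds shown alone.

In an ADME assay on MT4 cells (Homo sapiens) for cytotoxicity, read by MTT assay (on this read-out lower numbers stand for higher toxicity in this test and higher numbers for lower toxicity in this test), compound 1 `O=C1c2ccccc2C(=O)N1CCOC(=S)N(C(=O)c1cc(F)cc(F)c1)c1ccc(Cl)cc1` gives 59000 nM and compound 2 `O=C1c2ccccc2C(=O)N1CCOC(=S)N(C(=O)c1ccc(Cl)cc1Cl)c1ccc(Cl)cc1` gives 18000 nM while compound 3 `O=C1c2ccccc2C(=O)N1CCOC(=S)N(C(=O)c1cc([N+](=O)[O-])ccc1Cl)c1ccc(Cl)cc1` gives 45000 nM on the same shared core. Compound 3 thus stands in the upper part of this small range. The data show a 1.3-fold lower number from compound 1 to compound 3 (0.12 log units; within the scatter) which stays within the scatter, and a 2.5-fold higher number from compound 2 to compound 3 (0.40 log units; beyond the scatter) which goes beyond it. The next structure, compound 4 `O=C1c2ccccc2C(=O)N1CCOC(=S)N(C(=O)c1ccc2ccccc2c1)c1ccc(Cl)cc1` has not yet been measured. It carries naphthalen-2-yl in place of 2-chloro-5-nitrophenyl on a carbonyl carbon with the rest of the structure unchanged. Among the compounds with values here, all the measured steps exchange this same group, and the largest is a 3.3-fold lower number from compound 1 to compound 2 (0.52 log units; beyond the scatter) which is only modest. Within the data shown here, no measured compound carries naphthalen-2-yl, so these steps suggest a likely size for the change but give no firm direction. Compound 3 with 45000 nM sits near the upper end of the measured span, so any change is expected to lean towards a lower number. The expected move is a 1.5-fold lower number from compound 3 to compound 4 (0.18 log units; within the scatter) and nothing beyond the scatter is foreseen. For compound 4 the estimated value is 30000 nM with an expected range (12000 nM to 70000 nM).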

Compound 4, half-maximal cytotoxic concentration: 37000 nM
Estimate against measurement, compound 4: 1.2-fold (0.09 log units) below, within the range that was stated.
By their numbers in this assay, from the lowest: compound 2; then compounds 4, 3 and 1 (each within the scatter of the next).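

Swapping 2-chloro-5-nitrophenyl for naphthalen-2-yl on this carbonyl carbon keeps the heavy-atom count but removes the nitrogen, the oxygens, the chlorine and both hydrogen-bond acceptors, and adds a second six-membered aromatic ring of carbon only; even so, this assay shows a 1.2-fold lower number from compound 3 to compound 4 (0.09 log units; within the scatter). Within the data shown here, the earlier compounds had only substituted single aromatic rings at this position, so this is the first sign that a group with two such rings can sit here without a separation from the other reading, and the same holds against the difluorinated compound, with a 1.6-fold lower number from compound 1 to compound 4 (0.20 log units; within the scatter). Among these compounds, the one step beyond the scatter is a 2.1-fold higher number from compound 2 to compound 4 (0.31 log units; beyond the scatter), which is modest and leaves compound 2 as the only compound whose steps to all three others are printed as beyond the scatter.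

On these data alone, how a group of another kind on this carbonyl carbon, such as a cyclohexyl ring, a longer alkyl chain, an amine or a carboxylic acid, would read remains open. Nothing available here bears on why compound 2 stands apart from the other three.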